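The source may hold more compounds than are shown below. What is called first, only, known or untested is meant among the compounds shown, and "the series" means these compounds.

In a functional assay on KBVIN cells (Homo sapiens) for antiproliferative activity, read by sulforhodamine B assay, with a stated time of 3 days (on this read-out lower numbers stand for an effect already at smaller amounts and higher numbers for an effect only at larger amounts of compound), compound 1 (`CCC1=C(O)c2c(oc(-c3ccc(C)c(Cl)c3)cc2=O)C(CC)(CC)C1=O`) gives 2.15 uM and compound 2 (`CCC1=C(O)c2c(oc(-c3ccc(O)c(C)c3C)cc2=O)C(CC)(CC)C1=O`) gives 2.75 uM. Within the data shown here, these are the only two measurements so far, and they lie within the scatter of each other, so compound 2 stands level with compound 1. Compound 3 (`CCC1=C(O)c2c(oc(-c3cc(C)ccc3F)cc2=O)C(CC)(CC)C1=O`) has not yet been measured. It carries 2-fluoro-5-methylphenyl in place of 4-hydroxy-2,3-dimethylphenyl on an aromatic carbon next to the ring oxygen: 2-fluoro-5-methylphenyl in place of 4-hydroxy-2,3-dimethylphenyl on an aromatic carbon. Among the measured compounds shown here, only one measured step bears on this change, an exchange of one substituted phenyl group for another on the same carbon: a 1.3-fold higher number from compound 1 to compound 2 (0.11 log units; within the scatter). With so small a precedent, no direction can be argued, and the size of the change is expected to stay within the scatter. The expected step is a 1.1-fold lower number from compound 2 to compound 3 (0.04 log units; within the scatter). For compound 3 the estimated value is 2.5 uM, with an expected range from 1 uM to 6 uM.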

Compound 3, concentration for half-maximal effect: 3.24 uM
Estimate against measurement, compound 3: 1.3-fold (0.11 log units) below; measured number inside the range.
By their numbers in this assay, from the lowest: compounds 1, 2 and 3 (each within the scatter of the next).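

In this assay, 2-fluoro-5-methylphenyl in place of 4-hydroxy-2,3-dimethylphenyl gives a 1.2-fold higher number from compound 2 to compound 3 (0.07 log units; within the scatter) even though the entering group counts 0 hydrogen-bond donors and 0 hydrogen-bond acceptors, where the leaving group counts 1 of each. The same group in place of 3-chloro-4-methylphenyl gives a 1.5-fold higher number from compound 1 to compound 3 (0.18 log units; within the scatter) so all three substituted phenyl groups on this aromatic carbon next to the ring oxygen stand level, and the hydroxyl group of compound 2 is not required for that level among these compounds. No measurement available here explains this evenness. The compounds shown leave open whether a phenyl group carrying an amine or a carboxylic acid would stay level in this assay as well. They also leave open what a longer alkyl chain in place of the phenyl ring would give on this carbon.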